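The source may hold more compounds than are shown below. What is called first, only, known or untested is meant among the compounds shown, and "the series" means these compounds.

Measured in an ADME assay on NIH3T3 cells (Mus musculus) for cytotoxicity, read by neutral red uptake, with a stated time of 24 h; on this read-out higher numbers stand for lower toxicity in this test and lower numbers for higher toxicity in this test:
- compound 1 `Clc1ccc(-c2ccc(CNCC3CCNCC3)o2)c(-c2ccccc2)c1`: 20 uM
- compound 2 `COc1ccccc1-c1ccc(CNCC2CCNCC2)o1`: 53 uM

Among the compounds with values here, only these two compounds have numbers so far. Compound 2 has the higher number in this assay, which means lower toxicity in this test, and its gap to compound 1 lies beyond the scatter. The two compounds differ in more than one place, so their gap does not isolate any single structural change.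

Compound 3 `Oc1ccccc1-c1ccc(CNCC2CCNCC2)o1` has not yet been measured. Its structure departs from compound 2 in one place: hydrogen in place of methyl on an oxygen on an aromatic ring. In words, hydrogen stands in place of methyl on an oxygen on an aromatic ring, which turns methoxy to hydroxy.

Within the data shown here, no measured pair shows this change, so there is no direct precedent for its size or direction. The expectation therefore starts from compound 2 at 53 uM, and no step beyond the scatter is expected in this assay. The estimated move is a 1.0-fold higher number from compound 2 to compound 3 (0.02 log units; within the scatter), and this expected step has no firm direction. Compound 3 is estimated at 55 uM, with an expected range from 22 uM to 130 uM.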

Compound 3, half-maximal toxic concentration: 7 uM
Compound 3: middle estimate off by 7.9-fold (0.90 log units), on the high side, outside the stated range (below it).
By their numbers in this assay, from the lowest: compound 3; then compound 1; then compound 2.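

In this assay, the oxygen on the aromatic ring proves to be a sensitive place: going from methoxy to hydroxy gives a 7.6-fold lower number from compound 2 to compound 3 (0.88 log units; beyond the scatter), which here means higher toxicity in this test. The loss of a single methyl, with one carbon leaving and no ring or net charge involved, is enough on its own to move the read-out. The gap between compound 1 and compound 2 could not show this, since those two differ in more than one place. Nothing measured here speaks to why so small a change has so large an effect.

The compounds shown leave open whether the lower number belongs to the free hydroxy itself or simply to the absence of the methyl, and an ethoxy group, a fluorine or an amino group in place of the methoxy would begin to separate these readings. Within the data shown here, they also leave open whether the same change would give a similar step on a different core, such as the one carried by compound 1.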